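The source may report more compounds than this note shows. Statements on the series, on what has been measured and on what is new or still open speak of the compounds shown alone.

Measured compounds:
compound 1, `CC(C)(C)Cc1csc(N)c1C(=O)c1ccc(Cl)cc1`: 1%
compound 2, `COc1cccc(-c2sc(N)c(C(=O)c3ccc(Cl)cc3)c2CC(C)(C)C)c1`: 1%

In an assay on CHO cells for displacement of a labelled ligand from adenosine receptor A1 (Homo sapiens), read by scintillation counting, tested at 10 uM (a lower number here means less inhibition, a higher number more inhibition at the concentration tested (going by the name of the read-out)), compound 1 gives 1%. Where compound 1 has a hydrogen on an aromatic carbon, a 3-methoxyphenyl group is carried by compound 2, which gives 1%. The step of no change at the digits printed from compound 1 to compound 2 (within the scatter) shows that adding this six-membered aromatic ring left the read-out where it was, so compound 2 stands level with compound 1 at the digits shown, and both sit at the very bottom of the scale in this assay.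

The unmeasured compound 3, `CC(C)(C)Cc1c(-c2cn[nH]c2)sc(N)c1C(=O)c1ccc(Cl)cc1`, differs from compound 2 in one place: 1H-pyrazol-4-yl in place of 3-methoxyphenyl on an aromatic carbon. Within the data shown here, only one measured step touches this position, no change at the digits printed from compound 1 to compound 2 (within the scatter), and it was within the scatter. Among the measured compounds shown here, no measured pair shows what a pyrazolyl group does at this carbon, so the expectation rests on compound 2 with its 1% and on the flat step before it. The step expected here, a number 1 percentage points higher from compound 2 to compound 3 (within the scatter), is none beyond the scatter. Compound 3 is therefore estimated at 2%, with a range from 0% to 12%.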

Compound 3, a percentage reported as inhibition, at one concentration (the size of the read-out at that concentration, not a potency): 1%
Compound 3: middle estimate off by 1 percentage points, on the high side; low and high end bracket the measured number.
By their numbers in this assay, from the lowest: compounds 1, 2 and 3 (each within the scatter of the next).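

Replacing 3-methoxyphenyl with 1H-pyrazol-4-yl swaps a six-membered aromatic ring of carbon only for a five-membered aromatic ring with 2 hetero atoms and adds a hydrogen-bond donor, yet the result is no change at the digits printed from compound 2 to compound 3 (within the scatter) in this assay. Measured against the hydrogen at this carbon, the pyrazolyl group also gives no change at the digits printed from compound 1 to compound 3 (within the scatter), so this position now has two different aromatic rings that both read the same as the unsubstituted compound. With all three compounds at the very bottom of the scale, this shows that neither ring brings out inhibition at the concentration tested, but it cannot rank the groups, and nothing available explains the flat result.

The compounds shown leave open whether any group on this carbon can raise the read-out at all, such as an aminomethyl group or a carboxylic acid, which would put a basic amine or an acid where these aromatic rings now sit. They also leave open whether changes elsewhere on the shared core would do so, for instance a shorter chain in place of the neopentyl group or another atom in place of the chlorine on the 4-chlorophenyl ring.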